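Isomeric aryl substitution in a weakly cytotoxic series

The source may hold more compounds than are shown below. What is called first, only, known or untested is meant among the compounds shown, and "the series" means these compounds.

The series shares one core, varied only at the aryl group on the aromatic nitrogen. Compound 1 `Cn1ccc2c(Oc3ccc(NC(=O)c4cc5cccnc5n(-c5ccc(Cl)cc5)c4=O)cc3F)ncnc21` carries a chlorophenyl there and in a functional assay on MCF7 cells (Homo sapiens) for cytotoxicity, read by MTT assay, with a stated time of 72 h (on this read-out lower numbers stand for stronger inhibition and higher numbers for weaker inhibition), compound 1 gives 75000 nM. Compound 2 `Cn1ccc2c(Oc3ccc(NC(=O)c4cc5cccnc5n(-c5ccc(Br)cc5)c4=O)cc3F)ncnc21` carries a bromophenyl; in this assay compound 2 gives 59400 nM. Going by the values given here, the step of a 1.3-fold lower number from compound 1 to compound 2 (0.10 log units; within the scatter) is the only single-point comparison available, and it shows no movement beyond the scatter.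

Compound 3 `Cn1ccc2c(Oc3ccc(NC(=O)c4cc5cccnc5n(-c5ccc(C(F)(F)F)c(Cl)c5)c4=O)cc3F)ncnc21` carries a 3-chloro-4-(trifluoromethyl)phenyl and in this assay compound 3 gives "not active" (no number reported), with no number reported. On the numbers shown it therefore stands apart from compound 1 and compound 2, which both gave weak but measurable values.

Compound 4 `Cn1ccc2c(Oc3ccc(NC(=O)c4cc5cccnc5n(-c5ccc(C(F)(F)F)cc5Cl)c4=O)cc3F)ncnc21` differs from compound 3 by 2-chloro-4-(trifluoromethyl)phenyl in place of 3-chloro-4-(trifluoromethyl)phenyl on an aromatic nitrogen. Among the compounds with values here, no measured step bears directly on this change; the one step in hand, a 1.3-fold lower number from compound 1 to compound 2 (0.10 log units; within the scatter), concerns a different exchange and was within the scatter. With compound 3 inactive and compound 1 and compound 2 both weak, no step beyond the scatter is expected in this assay in either direction, and a result without a number is a real possibility. For compound 4 in this assay the expected value is 80000 nM, within 30000 nM to 200000 nM.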

Compound 4, half-maximal inhibitory concentration: "not active" (no number reported)
Compound 4 has no reported number here, so the estimate cannot be set against anything.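

In this assay compound 3 and compound 4 both gave "not active" with no number, so no step can be read between these two isomers. Nothing available bears on this result. From the compounds shown here alone, what remains open is whether 3-chloro-4-(trifluoromethyl)phenyl and 2-chloro-4-(trifluoromethyl)phenyl differ at all on this read-out.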